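Amino on the ring amide nitrogen of compound 3

The source may hold more compounds than are shown below. What is called first, only, known or untested is meant among the compounds shown, and "the series" means these compounds.

Measured in a functional assay on P388 cells (Mus musculus) for cytotoxicity; on this read-out lower numbers stand for stronger inhibition and higher numbers for weaker inhibition:
- compound 1 `COc1ccc(C[C@H]2C(=O)N(C)[C@@H](C)C(=O)N(C)[C@H]3Cc4ccc(cc4)Oc4cc(ccc4OC)C[C@@H](C(=O)N(C)[C@H](C)C(=O)N(C)[C@@H](C)C(=O)N2C)N(C)C3=O)cc1`: 3100 nM
- compound 2 `COc1ccc(C[C@H]2C(=O)N(C)[C@@H](C)C(=O)N(C)[C@H]3Cc4ccc(cc4)Oc4cc(c(Br)cc4OC)C[C@@H](C(=O)N(C)[C@H](C)C(=O)N(C)[C@@H](C)C(=O)N2C)N(C)C3=O)cc1`: > 110000 nM (a limit of the assay)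
- compound 3 `COc1ccc(C[C@H]2C(=O)N(C)[C@@H](C)C(=O)N(C)[C@H]3Cc4ccc(cc4)Oc4cc(ccc4OC)C[C@@H](C(=O)N(C)[C@H](C)C(=O)N[C@@H](C)C(=O)N2C)N(C)C3=O)cc1`: 10000 nM

Compound 3, at 10000 nM, holds the higher of the two actual numbers in this assay, and its nearest neighbour is compound 1 at 3100 nM. The value of compound 2 is only a limit, > 110000 nM.

Compound 4 `COc1ccc(C[C@H]2C(=O)N(C)[C@@H](C)C(=O)N(C)[C@H]3Cc4ccc(cc4)Oc4cc(ccc4OC)C[C@@H](C(=O)N(C)[C@H](C)C(=O)N(N)[C@@H](C)C(=O)N2C)N(C)C3=O)cc1` carries amino in place of hydrogen on an amide-type nitrogen in a ring, (amino in place of hydrogen on an amide-type nitrogen in a ring). This is the same nitrogen that separates compound 1 from compound 3. Hydrogen in place of methyl there gave a 3.2-fold higher number from compound 1 to compound 3 (0.51 log units; beyond the scatter), a modest step, and this is the most relevant measurement. Bromo in place of hydrogen on an aromatic carbon gave an at least 35-fold higher number from compound 1 to compound 2 (1.55 log units; beyond the scatter), a large step ending at a limit (the limit of > 110000 nM in this assay, at which 1 of the 3 values shown sits), but it is a different change and offers little guidance here. Within the data shown here, no measured compound carries amino at this nitrogen, so the direction remains uncertain, with a slight lean towards a higher number. The expected change is a 1.2-fold higher number from compound 3 to compound 4 (0.08 log units; within the scatter), and nothing larger than a modest step is anticipated. For compound 4 the estimated value is 12000 nM, with an expected range from 3000 nM to 50000 nM.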

Compound 4, half-maximal inhibitory concentration: 49000 nM
For compound 4 the middle estimate is 4.1-fold (0.61 log units) below the measured one; the range from low to high includes it.
By their numbers in this assay, from the lowest: compound 1; then compound 3; then compound 4. At a limit, above all of these: compound 2.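

In this assay, the amide-type nitrogen in the ring now has a third substituent read, and a 4.9-fold higher number from compound 3 to compound 4 (0.69 log units; beyond the scatter): amino on this nitrogen does not return the read-out towards that of the methyl compound, but moves it further the same way. Against methyl the change is larger still, a 16-fold higher number from compound 1 to compound 4 (1.20 log units; beyond the scatter), whereas removing the methyl alone gave a 3.2-fold higher number from compound 1 to compound 3 (0.51 log units; beyond the scatter), so among these three compounds methyl gives the lowest number, hydrogen a higher one and amino the highest. Methyl and amino each bring one heavy atom, so that count alone does not set the read-out at this nitrogen, and nothing measured here gives a cause for the steps.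

On these data alone, whether a longer chain such as ethyl, or a hydroxyl group, on this nitrogen would stay near compound 1 or move towards compound 4 remains open. Also open, as far as these compounds go, is whether amino on another ring amide nitrogen of the shared core would give a step of similar direction and size.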